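A nitro swap on a compound at the limit

This account rests on a few compounds, and the source may have more. Where it says the series, first, only, none or still open, it means among the compounds named here.

Compound 1 `C=C1CC[C@H]2C(C)(C)CCC[C@]2(C)[C@H]1CCC(C)CC(=O)O` gives > 200000 nM as a limit
Compound 2 `C=C1CC[C@H]2C(C)(C)CCC[C@]2(C)[C@H]1CCC(C)CC(=O)OC` gives > 200000 nM as a limit
Compound 3 `Cc1ccc(/C=C2\CC[C@H]3C(C)(C)CCC[C@]3(C)[C@H]2CCC(C)CC(=O)O)cc1` gives > 200000 nM as a limit

Each of these values comes from a functional assay on MCF7 cells (Homo sapiens) for cytotoxicity, read by MTT assay, with a stated time of 24 h (a lower number here means a stronger inhibitor, a higher number a weaker inhibitor), and the record so far is the limit of > 200000 nM in this assay, at which 3 of the 3 values shown sit, with no readable number among them. Compound 3 carries a 4-methylphenyl group on the shared core, and compound 3 stands at > 200000 nM as a limit.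

Compound 4 `CC(CC[C@H]1/C(=C/c2ccc([N+](=O)[O-])cc2)CC[C@H]2C(C)(C)CCC[C@]12C)CC(=O)O` differs from compound 3 at that group alone, which becomes 4-nitrophenyl: nitro in place of methyl on an aromatic carbon with nitro in place of methyl on an aromatic carbon, para to a large group.

Within the data shown here, only one measured step exists, a step that the two limits leave unreadable from compound 1 to compound 2 and it lies elsewhere in the molecule. Among the measured compounds shown here, no measured step touches the aromatic ring, so no size can be carried over to this change. What is expected in this assay therefore rests on compound 3 at > 200000 nM as a limit, and the expectation is no step beyond the scatter in either direction. The estimate means a number no higher from compound 3 to compound 4 (the limit leaves the size open) as the expected step. Compound 4 is expected at 200000 nM as an estimate, with an estimated range from 80000 nM to 400000 nM in this assay.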

Compound 4, half-maximal inhibitory concentration: > 200000 nM
Compound 4 gave a limit, no number; the forecaster's own chance of this, stated with the estimate: 70%; the middle value sits exactly at the limit.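

No step can be read from compound 3 to compound 4 in this assay, since each gives only a limit and not a number: the limit of > 200000 nM in this assay, at which 4 of the 4 values shown sit. The compounds shown leave open whether 4-nitrophenyl in place of 4-methylphenyl makes any difference to the strength of these compounds, and how strong any of them really is.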